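This account rests on a few compounds, and the source may have more. Where it says the series, first, only, none or still open, it means among the compounds named here.

Working notes on the amide series. In a functional assay on PC-3 cells (Homo sapiens) for antiproliferative activity, read by MTT assay, with a stated time of 48 h (on this read-out lower numbers stand for stronger inhibition and higher numbers for weaker inhibition), compound 1 `CCn1c(C(=O)NCCN(C)C)ccc1C(CC)(CC)c1ccc(OCCC(O)(CC)CC)c(C)c1` gives 870 nM. Compound 2 `CCn1c(C(=O)N(CCC#N)CCC#N)ccc1C(CC)(CC)c1ccc(OCCC(O)(CC)CC)c(C)c1` gives > 50000 nM, which is a limit of the assay and not a number. Compound 2 therefore stands at the limit of > 50000 nM in this assay, at which 1 of the 2 values shown sits, and no exact position can be given for it.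

Compound 3 `CCn1c(C(=O)Nc2ccc(OC(F)(F)F)cc2)ccc1C(CC)(CC)c1ccc(OCCC(O)(CC)CC)c(C)c1` keeps the shared core and changes only the group on the carbonyl carbon: a group of 12 heavy atoms (7 carbon, 1 nitrogen, 1 oxygen, 3 fluorine; one six-membered aromatic ring of carbon only) in place of a group of 9 heavy atoms (6 carbon, 3 nitrogen; no ring), on a carbonyl carbon. Within the data shown here, the one measured step at this place is an at least 57-fold higher number from compound 1 to compound 2 (1.75 log units; beyond the scatter), which is large and beyond the scatter. Neither measured compound carries an aromatic ring at this place, so the size of the coming step is poorly fixed.

Compound 3 keeps the amide hydrogen, as compound 1 does and compound 2 does not. Given an at least 57-fold higher number from compound 1 to compound 2 (1.75 log units; beyond the scatter), a moderate to large move toward a lower number is expected in this assay, although a second limit remains possible. For compound 3 the estimated value is 6000 nM, with an expected range from 800 nM to 40000 nM. The expected change is an at least 8.3-fold lower number from compound 2 to compound 3 (0.92 log units; beyond the scatter).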

Compound 3, half-maximal inhibitory concentration: > 50000 nM
Compound 3 ended at the assay's limit (the forecaster's own chance of this, stated with the estimate: 25%); at least 8.3-fold (0.92 log units) between middle value and limit.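

In this assay compound 3 also ends at a limit of the assay and not at a number, as compound 2 does: the limit of > 50000 nM in this assay, at which 2 of the 3 values shown sit.

Placing 4-(trifluoromethoxy)phenyl on the amide-type nitrogen in place of 2-(dimethylamino)ethyl gives an at least 57-fold higher number from compound 1 to compound 3 (1.75 log units; beyond the scatter), so the amide hydrogen, present in both compounds, is not enough on its own to keep a measurable value in this series. The step from compound 2 to compound 3 cannot be read, as both ends are limits. The two quite different groups, one with nitrile ends and no ring and one with an aromatic ring, leave compound 1 as the only one of the three with a measured number at this place. Compound 1 gives 870 nM.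

As far as these compounds go, what stays open is whether the dimethylamino group or the ethyl chain of compound 1 matters more, which a 3-(dimethylamino)propyl or a 2-hydroxyethyl amide would help to separate. From the compounds shown here alone, it also stays open whether the result for compound 3 belongs to the aromatic ring or to the trifluoromethoxy group, a question that a plain phenyl or a benzyl amide would address.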